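Sulfonylating the ring amine of compound 2

The source may report more compounds than this note shows. Statements on the series, on what has been measured and on what is new or still open speak of the compounds shown alone.

Two compounds have been measured so far in a functional assay on HepG2 cells (Homo sapiens) for cytotoxicity, read by MTT assay, with a stated time of 24 h (on this read-out higher numbers stand for weaker inhibition and lower numbers for stronger inhibition), and give these values:
compound 1 `O=C1/C(=C/c2cccnc2)CN(S(=O)(=O)c2ccc([N+](=O)[O-])cc2)C/C1=C\c1ccccc1C(F)(F)F` with 9370 nM
compound 2 `O=C1/C(=C/c2ccncc2)CNC/C1=C\c1ccccc1C(F)(F)F` with 6130 nM

In this assay compound 2 gives 6130 nM and thus stands within the usual scatter of compound 1 at 9370 nM in this assay, so the two numbers do not separate the pair. The next compound to be tested is compound 3 `O=C1/C(=C/c2ccncc2)CN(S(=O)(=O)c2ccc([N+](=O)[O-])cc2)C/C1=C\c1ccccc1C(F)(F)F` and its structure differs from that of compound 2 by (4-nitrophenyl)sulfonyl in place of hydrogen on an amine nitrogen in a ring in one place: (4-nitrophenyl)sulfonyl in place of hydrogen on an amine nitrogen in a ring. For the measured compounds named here, no measured pair shows this change on its own, so there is no direct step to lean on. Going by the values given here, the one measured compound bearing (4-nitrophenyl)sulfonyl is compound 1, whose 9370 nM lies within the scatter of the value for compound 2 and so points to no clear direction. No step beyond the scatter is therefore expected in this assay for this change. The expected size is a 1.1-fold higher number from compound 2 to compound 3 (0.03 log units; within the scatter) as an estimate only. For compound 3 the estimated value is 6500 nM with an expected range from 2500 nM to 15000 nM in this measurement.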

Compound 3, half-maximal inhibitory concentration: 13400 nM
Compound 3: the middle estimate sits 2.1-fold (0.31 log units) below what was measured; the range from low to high includes it.
By their numbers in this assay, from the lowest: compounds 2, 1 and 3 (each within the scatter of the next, the first and the last beyond it).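

In this assay, (4-nitrophenyl)sulfonyl in place of hydrogen on an amine nitrogen in a ring gives a 2.2-fold higher number from compound 2 to compound 3 (0.34 log units; beyond the scatter) and so a modest loss of inhibition, which is the first reading of this change on its own and the first separation beyond the scatter among these compounds. Compound 1 could not show this, since its value lay within the scatter of compound 2 and it also differs from compound 2 in the pyridine group. Pyridin-4-yl in place of pyridin-3-yl gives a 1.4-fold higher number from compound 1 to compound 3 (0.16 log units; within the scatter) with the sulfonyl group held constant, so that swap does not separate the two sulfonylated compounds, and nothing measured here accounts for either step.

Whether the sulfonyl step also holds with pyridin-3-yl remains open, as the compounds shown carry that group only together with (4-nitrophenyl)sulfonyl. From the compounds shown here alone, it is also open whether the nitro group matters to the step, or whether a plain benzenesulfonyl, an acetyl or a methyl on the same amine nitrogen would move the number in the same way.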